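The compounds below may be only part of what the source reports. "The series", "measured", "known", "first", "only" and "open" are said of these compounds alone.

Three compounds sharing one core were examined in an ADME assay on RAW264.7 cells (Mus musculus) for cytotoxicity, read by MTT assay; on this read-out lower numbers stand for stronger inhibition and higher numbers for weaker inhibition: compound 1 (`CCCCCCOc1cccc(O)c1C(=O)/C=C/c1ccc(O)cc1`), compound 2 (`CCCCCCCCCCOc1cccc(O)c1C(=O)/C=C/c1ccc(O)cc1`) and compound 3 (`O=C(/C=C/c1ccc(O)cc1)c1c(O)cccc1OCC1CCCCC1`). Compound 1 gives > 30000 nM, which is a limit of the assay and not a number. Compound 2 gives > 30000 nM, also a limit. Compound 3 likewise gives only a limit, > 30000 nM. The whole record so far is therefore (the limit of > 30000 nM in this assay, at which 3 of the 3 values shown sit), and compound 3 has no measured rank among the others.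

Compound 4 (`O=C(/C=C/c1ccc(O)cc1)c1c(O)cccc1OCc1ccccc1`) carries phenyl in place of cyclohexyl on a saturated chain carbon bound to an oxygen on an aromatic ring. The measured steps that change this same group are a step that the two limits leave unreadable from compound 1 to compound 3 and a step that the two limits leave unreadable from compound 2 to compound 3. The chain extension, a step that the two limits leave unreadable from compound 1 to compound 2, gives no size either. Going by the values given here, no step of a known size or direction can therefore be expected in this assay, and another limit is the likeliest report. For compound 4 the estimated value is 35000 nM, with an expected range from 15000 nM to 80000 nM. This estimate means an expected step that the limit leaves unreadable from compound 3 to compound 4.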

Compound 4, half-maximal inhibitory concentration: > 30000 nM
Compound 4 was reported as a limit; the forecaster's own chance of this, stated with the estimate: 80%; the middle value does not contradict the limit.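

The steps to compound 4 from compound 1, compound 2 and compound 3 cannot be read in this assay, as each value is a limit and not a number: the limit of > 30000 nM in this assay, at which 4 of the 4 values shown sit.

The compounds shown leave open whether any of these changes alters cytotoxicity in this assay, and by how much.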